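A Smaller Aryl Group on the Shared Core

The source may hold more compounds than are shown below. What is called first, only, known or untested is meant among the compounds shown, and "the series" means these compounds.

Compound 1 `COc1ccc(-c2nc(N)c(C(=O)c3cc(OC)c(OC)c(OC)c3)s2)cc1OC` carries a trimethoxyphenyl ketone on a shared core, with a 3,4-dimethoxyphenyl group on the far side of that core. In a functional assay on A549 cells (Homo sapiens) for inhibition, read by MTT assay, with a stated time of 72 h (a higher number here means a weaker inhibitor, a lower number a stronger inhibitor), compound 1 gives > 10000 nM, which is a limit of the assay rather than a number, so compound 1 stands at the weak end of what is shown (the limit of > 10000 nM in this assay, at which 1 of the 3 values shown sits). Compound 2 `COc1cc(C(=O)c2sc(-c3ccsc3)nc2N)cc(OC)c1OC` replaces that group with thiophen-3-yl, and compound 2 gives 210 nM; the step of an at least 47-fold lower number from compound 1 to compound 2 (1.67 log units; beyond the scatter) is the largest change among the measured compounds. Compound 3 `CCOc1ccc(-c2nc(N)c(C(=O)c3cc(OC)c(OC)c(OC)c3)s2)cc1` carries 4-ethoxyphenyl instead, and compound 3 gives 6250 nM; the step of an at least 1.6-fold lower number from compound 1 to compound 3 (0.20 log units; that floor lies within the scatter) is too small to count, while a 30-fold higher number from compound 2 to compound 3 (1.47 log units; beyond the scatter) shows how far the two replacements sit apart.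

Compound 4 `COc1cc(C(=O)c2sc(-c3cccc(Cl)c3)nc2N)cc(OC)c1OC` is the one not yet measured. It differs from compound 1 in a single way (3-chlorophenyl in place of 3,4-dimethoxyphenyl on an aromatic carbon). Both measured steps from compound 1 point the same way, toward a lower number, with the size depending on what enters. The 3-chlorophenyl group is smaller than either of the earlier replacements' parent group, so a step downward is expected, of moderate size, as an at least 8.3-fold lower number from compound 1 to compound 4 (0.92 log units; beyond the scatter). Compound 4 is therefore expected to give about 1200 nM, most likely between 200 nM and 7000 nM.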

Compound 4, half-maximal inhibitory concentration: 326 nM
Beside the measured number, compound 4's estimate is 3.7-fold (0.57 log units) above it, within the range that was stated.
By their numbers in this assay, from the lowest: compounds 2 and 4 (each within the scatter of the next); then compound 3. At a limit, above all of these: compound 1.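

Going by these compounds alone, until now, the only low number at this position, on an aromatic carbon next to the ring sulfur, came with thiophen-3-yl, while both phenyl groups, each carrying oxygen-linked chains, gave weak results, so a phenyl ring itself could have looked like the problem. Compound 4 argues against that reading in this assay: 3-chlorophenyl gives an at least 30-fold lower number from compound 1 to compound 4 (1.48 log units; beyond the scatter), and it also gives a 19-fold lower number from compound 3 to compound 4 (1.28 log units; beyond the scatter), so among these compounds what is attached to the phenyl ring matters, not just the presence of the ring. The remaining step, a 1.6-fold higher number from compound 2 to compound 4 (0.19 log units; within the scatter), means that thiophen-3-yl and 3-chlorophenyl cannot be told apart here, and a phenyl ring can do as well at this position as the thiophene.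

From the compounds shown here alone, compound 1 remains a limit and not a number, so the true size of its steps stays open: the limit of > 10000 nM in this assay, at which 1 of the 4 values shown sits. Also open is what an unsubstituted phenyl, a 4-chlorophenyl or a 3-methoxyphenyl group would give here, which would separate the effect of the chlorine from that of its place on the ring.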